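The compounds below may be only part of what the source reports. "The series", "measured", "known", "first", "only" and "open" are said of these compounds alone.

In a functional assay on the whole organism (strain Sprague-Dawley) for inhibition, with Rattus norvegicus as the target (a higher number here means that more compound is needed for the effect, a lower number that less compound is needed), compound 1 `O=c1c(-c2nn[nH]n2)c[nH]c2ccccc12` reaches only a limit of the assay, > 20 mg/kg. Two neighbours of compound 1 have been measured. Compound 2 `O=c1c(-c2nn[nH]n2)c[nH]c2ccc(Cl)cc12` likewise gives only a limit, > 25 mg/kg. Compound 3 `CCc1ccc2c(=O)c(-c3nn[nH]n3)c[nH]c2c1` also gives only a limit, > 10 mg/kg. The step that the two limits leave unreadable from compound 1 to compound 2 and the step that the two limits leave unreadable from compound 1 to compound 3 therefore cannot be sized; the three limits (the limit of > 10 mg/kg in this assay, at which 1 of the 3 values shown sits), the limit of > 20 mg/kg in this assay, at which 1 of the 3 values shown sits, and the limit of > 25 mg/kg in this assay, at which 1 of the 3 values shown sits, are all that stands. Compound 4 `COc1cccc2c(=O)c(-c3nn[nH]n3)c[nH]c12` carries methoxy in place of hydrogen on an aromatic carbon. Both measured steps bear on this change, since each puts a group on an aromatic carbon of the shared core, yet neither has a readable size, so no direction beyond the scatter can be expected. Compound 4 is expected to give 30 mg/kg, between 10 mg/kg and 100 mg/kg, most probably as a further limit. The expected step that the limit leaves unreadable from compound 1 to compound 4 is thus essentially none.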

Compound 4, minimum effective dose: 0.312 mg/kg
For compound 4 the middle estimate is 96-fold (1.98 log units) above the measured one; the measured number lies below the stated range.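

In this assay, methoxy in place of hydrogen on an aromatic carbon, ortho to a fused ring and meta to a fused ring, gives an at least 64-fold lower number from compound 1 to compound 4 (1.80 log units; beyond the scatter). The steps to the chloro and ethyl compounds cannot be read, so this is the only change shown with a readable size, and compound 4 alone gives a number rather than a limit. Its step is itself bounded, since compound 1 stands only at a limit: the limit of > 20 mg/kg in this assay, at which 1 of the 4 values shown sits.

On these data alone, whether the gain belongs to methoxy or to this position stays open. The compounds shown hold neither hydroxy or ethoxy at this place nor methoxy on another aromatic carbon of the shared core.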